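Butyl on the oxygen-linked compound: working notes

This account rests on a few compounds, and the source may have more. Where it says the series, first, only, none or still open, it means among the compounds named here.

Compound 1 `CCCCC(Sc1ncnc2c1cnn2-c1ccccc1Cl)C(=O)Nc1nc(C)cs1`: 6.4
Compound 2 `COCCC(Sc1ncnc2c1cnn2-c1ccccc1Cl)C(=O)Nc1nc(C)cs1`: 4.8
Compound 3 `Cc1csc(NC(=O)COc2ncnc3c2cnn3-c2ccccc2Cl)n1`: 3.2

In a physicochemical assay for lipophilicity, read by HPLC, measured as octanol-water partition (a higher number here means a more lipophilic compound, a lower number a more polar compound), compound 3 stands lowest of the three at 3.2, beyond the scatter from both others. Compound 4 `CCCCC(Oc1ncnc2c1cnn2-c1ccccc1Cl)C(=O)Nc1nc(C)cs1` differs from it by butyl in place of hydrogen on a saturated chain carbon bound to a carbonyl carbon and an oxygen on an aromatic ring.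

Within the data shown here, the one measured step on this chain, methoxy in place of ethyl, is large: a number 1.60 log units lower from compound 1 to compound 2 (beyond the scatter). Among the measured compounds shown here, no measured step isolates butyl against hydrogen, or oxygen against sulfur. Compound 1, with butyl on the sulfur-linked carbon, gives 6.4, well above compound 3. A large rise is therefore expected, with an estimated a number 2.60 log units higher from compound 3 to compound 4 (beyond the scatter). Compound 4 is expected at 5.8, within an estimated 5.2 to 6.4.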

Compound 4, distribution coefficient: 5.7
For compound 4 the middle estimate is 0.10 log units above the measured one; the measured number falls inside the stated range.
By their numbers in this assay, from the lowest: compound 3; then compound 2; then compound 4; then compound 1.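

In this assay, butyl in place of hydrogen on a saturated chain carbon bound to a carbonyl carbon and an oxygen on an aromatic ring gives a large rise (a number 2.50 log units higher from compound 3 to compound 4 (beyond the scatter)). Among these compounds, this is the first measured step at this carbon that starts from hydrogen, and it shows that the oxygen-linked compounds respond strongly to butyl here. No measured evidence bears on the origin of this rise.

From the compounds shown here alone, the effect of a longer chain, an amine or a carboxylic acid at this carbon remains open. So does whether methoxy in place of ethyl on the butyl chain would give a similar step in the oxygen-linked compounds.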